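Moving the chlorine on the amide-bound phenyl ring

The compounds below may be only part of what the source reports. "The series", "measured", "known", "first", "only" and "open" are said of these compounds alone.

Measured compounds:
- compound 1, `Cc1noc(C)c1-c1cnc(N)c(Oc2ccc(C(=O)Nc3ccc(Cl)cc3)cc2)n1`: 14400 nM
- compound 2, `Cn1cc(-c2cnc(N)c(Oc3ccc(C(=O)Nc4ccccc4)cc3)n2)cn1`: 11600 nM
- compound 3, `Cn1cc(-c2cnc(N)c(Oc3ccc(C(=O)Nc4ccccc4Cl)cc3)n2)cn1`: 66900 nM

All three were tested in a functional assay on HepG2 cells (Homo sapiens) for inhibition, read by MTT assay, with a stated time of 72 h; on this read-out lower numbers stand for stronger inhibition and higher numbers for weaker inhibition. Compound 3 gives the highest number of the three and therefore the weakest inhibition; its nearest neighbour is compound 1, and compound 2 lies furthest below it. Compound 4, `Cn1cc(-c2cnc(N)c(Oc3ccc(C(=O)Nc4ccc(Cl)cc4)cc3)n2)cn1`, has not yet been measured. It differs from compound 3 only in the arrangement of the same atoms: 4-chlorophenyl in place of 2-chlorophenyl on an amide-type nitrogen.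

Within the data shown here, one measured step bears on this. Going from the plain phenyl amide of compound 2 to the 2-chlorophenyl amide of compound 3 gave a 5.8-fold higher number from compound 2 to compound 3 (0.76 log units; beyond the scatter), so the 2-chlorophenyl group is linked to the weakest result here. Compound 1 carries a 4-chlorophenyl amide on a different core and gives a number close to that of compound 2, which hints that the 4-chlorophenyl group does not carry the same penalty. Compound 4 is therefore expected to move back toward the level of compound 2, an estimated 4.5-fold lower number from compound 3 to compound 4 (0.65 log units; beyond the scatter). The estimate for compound 4 is 15000 nM, with a range of 6000 nM to 40000 nM.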

Compound 4, half-maximal inhibitory concentration: 11900 nM
Estimate against measurement, compound 4: 1.3-fold (0.10 log units) above; low and high end bracket the measured number.
By their numbers in this assay, from the lowest: compounds 2, 4 and 1 (each within the scatter of the next); then compound 3.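

In this assay, the same atoms arranged differently give a 5.6-fold lower number from compound 3 to compound 4 (0.75 log units; beyond the scatter) when 4-chlorophenyl takes the place of 2-chlorophenyl on the amide-type nitrogen, so among these compounds, where the chlorine sits on this ring matters, not simply whether it is there. Chloro in place of hydrogen as the 4-chlorophenyl amide gives a 1.0-fold higher number from compound 2 to compound 4 (0.01 log units; within the scatter) and therefore no readable change, while the swap of 3,5-dimethyl-1,2-oxazol-4-yl for 1-methyl-1H-pyrazol-4-yl gives a 1.2-fold lower number from compound 1 to compound 4 (0.08 log units; within the scatter) and likewise no readable change, which means that with a 4-chlorophenyl amide in place these two groups cannot be told apart here. Nothing available gives a measured reason for the gap between the 2-chlorophenyl and 4-chlorophenyl amides.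

Still open, from the compounds shown here alone, is whether a 2-chlorophenyl amide on the core of compound 1 would show the same weakening seen in compound 3. Going by these compounds, it is also open whether a methoxy group, an amine or a carboxylic acid in place of the chlorine of compound 4 would shift the number at all.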